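The compounds below may be only part of what the source reports. "The series", "measured", "known", "first", "only" and "open" are said of these compounds alone.

Measured in a functional assay on MDA-MB-435 cells (Homo sapiens) for cytotoxicity, read by MTT assay, with a stated time of 72 h; on this read-out higher numbers stand for weaker inhibition and lower numbers for stronger inhibition:
- Compound 1 `CS(=O)(=O)Oc1c(C(=O)NCc2ccc(F)cc2)nc(Br)c2cccnc12`: > 20000 nM (limit)
- Compound 2 `O=C(NCc1ccc(F)cc1)c1nc(NCCO)c2cccnc2c1O`: > 20000 nM (limit)
- Compound 3 `O=C(NCc1ccc(F)cc1)c1nc(Br)c2cccnc2c1NCCCNc1c(C(=O)NCc2ccc(F)cc2)nc(Br)c2cccnc12`: > 20000 nM (limit)

Compound 2 has no exact value on this read-out: compound 2 gives > 20000 nM, which is a limit and not a number. Going by the values given here, the series so far sits at the limit of > 20000 nM in this assay, at which 3 of the 3 values shown sit, so the three compounds cannot be ranked.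

Compound 4 `C[C@@H](CO)Nc1nc(C(=O)NCc2ccc(F)cc2)c(O)c2ncccc12` differs from compound 2 by methyl in place of hydrogen on a saturated chain carbon bound to a nitrogen on an aromatic ring and a saturated chain carbon. This is methyl in place of hydrogen on a saturated chain carbon bound to a nitrogen on an aromatic ring and a saturated chain carbon, turning 2-hydroxyethyl into 1-(hydroxymethyl)ethyl.

Among the compounds with values here, no measured step gives a size for this change. The expectation therefore rests on compound 2 at > 20000 nM and on (the limit of > 20000 nM in this assay, at which 3 of the 3 values shown sit). No shift beyond the usual scatter is expected in this assay, and a result reported only as a limit is the likeliest outcome. The expected size of a number no higher from compound 2 to compound 4 (the limit leaves the size open) is small, with no direction favoured. The estimate for compound 4 is 20000 nM, with an expected range of 7000 nM to 40000 nM.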

Compound 4, half-maximal inhibitory concentration: > 20000 nM
Compound 4: no number, only a limit (the forecaster's own chance of this, stated with the estimate: 75%); the middle value sits exactly at the limit.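

In this assay compound 4 gives > 20000 nM, a limit and not a number. Going by these compounds alone, compound 2 gives > 20000 nM, also a limit, so no step from it to compound 4 can be read. The compounds shown leave open whether any member of this series gives an exact number: the limit of > 20000 nM in this assay, at which 4 of the 4 values shown sit.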